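A few compounds are considered here, and "the series" means these few. Any claim that something is new, unique, unknown or untested is made for them only; others in the source may bear on it.

Of the compounds shown here, three sharing one core have been measured in an assay on HEK293 cells for displacement of a labelled ligand from Neuronal acetylcholine receptor; alpha4/beta2 (Homo sapiens), read by scintillation counting, with a stated time of 120 min; a lower number here means a stronger inhibitor, a higher number a weaker inhibitor. Compound 1 `Fc1cccc(-c2cn([C@@H]3CN4CCC3CC4)nn2)c1` gives 519 nM. Compound 2 `c1ccc(COc2cccc(-c3cn([C@@H]4CN5CCC4CC5)nn3)c2)cc1`, which carries benzyloxy in place of fluoro, gives 414 nM; the pair differ by a 1.3-fold lower number from compound 1 to compound 2 (0.10 log units; within the scatter). Compound 3 `FCCCOc1cccc(-c2cn([C@@H]3CN4CCC3CC4)nn2)c1`, carrying 3-fluoropropoxy, gives 1980 nM, the highest number of the three; the steps leading to it are a 3.8-fold higher number from compound 1 to compound 3 (0.58 log units; beyond the scatter) and a 4.8-fold higher number from compound 2 to compound 3 (0.68 log units; beyond the scatter).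

Compound 4 `FCCOc1cccc(-c2cn([C@@H]3CN4CCC3CC4)nn2)c1` has not yet been measured. It differs from compound 3 by fluoro in place of fluoromethyl on a saturated chain carbon, two bonds along the chain from an oxygen on an aromatic ring, so that 3-fluoropropoxy becomes 2-fluoroethoxy. Within the data shown here, none of the measured steps alters a chain in this way. The step of a 3.8-fold higher number from compound 1 to compound 3 (0.58 log units; beyond the scatter) shows that placing a fluorinated chain on the oxygen raised the number, and a 4.8-fold higher number from compound 2 to compound 3 (0.68 log units; beyond the scatter) shows that exchanging phenyl for 2-fluoroethyl on that chain carbon also raised it, but neither says how the length of the fluorinated chain matters. The expectation in this assay is therefore a step of a 1.5-fold lower number from compound 3 to compound 4 (0.18 log units; within the scatter), small and inside the scatter, leaning toward a lower number. Compound 4 is estimated at 1300 nM, with a range from 500 nM to 3500 nM.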

Compound 4, inhibition constant: 1260 nM
Compound 4: the middle estimate sits 1.0-fold (0.01 log units) above what was measured; low and high end bracket the measured number.
By their numbers in this assay, from the lowest: compounds 2 and 1 (each within the scatter of the next); then compounds 4 and 3 (each within the scatter of the next).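

In this assay, shortening 3-fluoropropoxy to 2-fluoroethoxy on the saturated chain carbon, two bonds along the chain from an oxygen on an aromatic ring, gives a 1.6-fold lower number from compound 3 to compound 4 (0.20 log units; within the scatter) and so leaves the two fluorinated chains indistinguishable at this position. The higher number seen with compound 3 is also not confined to 3-fluoropropoxy, since the shorter chain shows a 2.4-fold higher number from compound 1 to compound 4 (0.39 log units; beyond the scatter) and a 3.0-fold higher number from compound 2 to compound 4 (0.48 log units; beyond the scatter) and so both fluorinated chains stand apart from the fluoro and benzyloxy compounds, with no compound shown going against this. Nothing in the material available explains why these chains differ from fluoro and benzyloxy.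

Chains without fluorine, such as ethoxy or propoxy, are absent from the compounds shown, so the contribution of the fluorine cannot be separated from that of the chain itself. Also open, going by these compounds, is whether a longer chain such as 4-fluorobutoxy would stay level with these two, or whether a terminal hydroxyl in place of the fluorine would change the number in this assay at all.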